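This account rests on a few compounds, and the source may have more. Where it says the series, first, only, none or still open, it means among the compounds named here.

Series notes. The shared core carries a trisubstituted phenyl and an enone whose carbonyl bears a varied aryl group. Compound 1 `COc1cc(-c2cc(/C=C/C(=O)c3ccc(N)cc3)[nH]n2)cc(OC)c1OC` gives 6720 nM in a functional assay on LOX IMVI cells (Homo sapiens) for inhibition, read by sulforhodamine B assay, with a stated time of 48 h; a lower number here means that less compound is tolerated, a higher number that more compound is tolerated. Compound 2 `COc1cc(-c2cc(/C=C/C(=O)c3ccc(Cl)c(Cl)c3)[nH]n2)cc(OC)c1OC` gives 78400 nM in this assay. Compound 3 `COc1ccc(C(=O)/C=C/c2cc(-c3cc(OC)c(OC)c(OC)c3)n[nH]2)cc1OC` gives 5530 nM in this assay, the lowest of the three numbers; compound 1 sits nearest to it and compound 2 furthest. The steps read a 1.2-fold lower number from compound 1 to compound 3 (0.08 log units; within the scatter), a 12-fold higher number from compound 1 to compound 2 (1.07 log units; beyond the scatter) and a 14-fold lower number from compound 2 to compound 3 (1.15 log units; beyond the scatter).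

Compound 4 `COc1cc(-c2cc(/C=C/C(=O)c3ccc(F)c(F)c3)[nH]n2)cc(OC)c1OC` is not yet measured in this assay. The change from compound 3 is 3,4-difluorophenyl in place of 3,4-dimethoxyphenyl on a carbonyl carbon. Going by these compounds, the step that bears on it is a 14-fold lower number from compound 2 to compound 3 (1.15 log units; beyond the scatter), which places the dihalogenated aryl well above the dimethoxy aryl; the difluoro case is untested, and the amino aryl of compound 1 adds nothing on halogens. A step upward beyond the scatter is therefore expected, plausibly smaller than that seen with the dichloro analogue. For compound 4 the estimate in this assay is 25000 nM, with a range of 6000 nM to 100000 nM. This estimate corresponds to an expected step of a 4.5-fold higher number from compound 3 to compound 4 (0.66 log units; beyond the scatter).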

Compound 4, concentration lethal to 50% of the cells: 41500 nM
For compound 4 the middle estimate is 1.7-fold (0.22 log units) below the measured one; measured number inside the range.
By their numbers in this assay, from the lowest: compounds 3 and 1 (each within the scatter of the next); then compounds 4 and 2 (each within the scatter of the next).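

In this assay, the 3,4-difluorophenyl group reads like the 3,4-dichlorophenyl group, with a 1.9-fold lower number from compound 2 to compound 4 (0.28 log units; within the scatter), so the high number of compound 2 is not confined to the chlorine pair. Replacing the other two aryl groups gives a 7.5-fold higher number from compound 3 to compound 4 (0.88 log units; beyond the scatter) and a 6.2-fold higher number from compound 1 to compound 4 (0.79 log units; beyond the scatter), which places both dihalogenated aryl groups apart from the 3,4-dimethoxyphenyl and 4-aminophenyl groups at this carbonyl carbon, with no listed compound going against this split. No measurement on hand accounts for this split.

The compounds shown cannot separate an effect of the two halogens from the loss of the methoxy or amino groups, since they include no unsubstituted phenyl and no aryl with a single halogen. Going by these compounds, how a nitrile or a carboxylic acid on this aryl would read also remains open.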